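The source may hold more compounds than are shown below. What is called first, only, known or untested is meant among the compounds shown, and "the series" means these compounds.

Of the compounds shown here, two have been measured so far in a functional assay on HT-29 cells (Homo sapiens) for antiproliferative activity, read by MTT assay, with a stated time of 72 h; on this read-out lower numbers stand for stronger inhibition and higher numbers for weaker inhibition. Compound 1 `COc1cc2c(Oc3c(F)cc(NC(=O)NN4C(=O)C(C)SC4c4c(F)cccc4F)cc3F)ccnc2cc1OCCCN1CCCC1` gives 670 nM in this assay. Compound 2 `CCN1CCN(CCCOc2cc3nccc(Oc4c(F)cc(NC(=O)NN5C(=O)CSC5c5c(F)cccc5F)cc4F)c3cc2OC)CC1` gives 73 nM in this assay, the lower of the two numbers, and the gap between compound 1 and compound 2 is wider than the scatter of repeated measurements. Compound 1 and compound 2 differ from each other in more than one place, so that gap cannot be tied to any single change.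

Compound 3 `COc1cc2c(Oc3c(F)cc(NC(=O)NN4C(=O)CSC4c4c(F)cccc4F)cc3F)ccnc2cc1OCCCN1CCC(N2CCCCC2)CC1` has not yet been measured. It differs from compound 2 in one place: 4-(piperidin-1-yl)piperidin-1-yl in place of 4-ethylpiperazin-1-yl on a saturated chain carbon, three bonds along the chain from an oxygen on an aromatic ring. Among the measured compounds shown here, both groups are amine-containing rings at the end of the same three-carbon chain, and no measured pair shows what exchanging one for the other does. Nothing in the two values in hand speaks for a large shift in either direction, so the expected step is a 1.2-fold higher number from compound 2 to compound 3 (0.07 log units; within the scatter), a change within the usual scatter. Compound 3 is therefore estimated at 85 nM in this assay, with a likely range from 30 nM to 250 nM.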

Compound 3, half-maximal inhibitory concentration: 280 nM
Estimate against measurement, compound 3: 3.3-fold (0.52 log units) below; measured number outside the range, above it.
By their numbers in this assay, from the lowest: compound 2; then compound 3; then compound 1.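

Among the compounds shown here, this is the first comparison that changes one place only, and it shows that the group on a saturated chain carbon, three bonds along the chain from an oxygen on an aromatic ring, is not interchangeable in this assay. Putting 4-(piperidin-1-yl)piperidin-1-yl in place of 4-ethylpiperazin-1-yl gives a 3.8-fold higher number from compound 2 to compound 3 (0.58 log units; beyond the scatter) and so weakens inhibition, a modest step but a real one, even though both groups carry no net charge and have the same counts of hydrogen-bond donors and acceptors. No measurement of any property of these two groups is at hand to account for the step.

The entering group has more heavy atoms and a second ring, and this one pair cannot separate those differences from each other or show how a smaller group such as morpholin-4-yl or a simple dimethylamine would behave at this position. From the compounds shown here alone, compound 1 still differs from both other compounds in more than one place, so what its own changes contribute remains open.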